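Shortening the fatty chain of a sulfonated glycolipid

The source may hold more compounds than are shown below. What is called first, only, known or untested is meant among the compounds shown, and "the series" means these compounds.

Compound 2, `CCCCCCCCCCCCCCCCCC(=O)OCC(CO)O[C@@H]1O[C@H](CS(=O)(=O)O)[C@@H](O)[C@H](O)[C@H]1O`, stands at the top of the two numbers seen so far: in an assay on isolated protein for inhibition of RAC-alpha serine/threonine-protein kinase (Homo sapiens), read by ELISA, tested at 100 uM (a lower number here means less inhibition, a higher number more inhibition at the concentration tested (going by the name of the read-out)), compound 2 gives 86%. For the measured compounds named here, its only comparison, compound 1, `CCCCCCCCO[C@@H]1O[C@H](CN)[C@@H](O)[C@H](O)[C@H]1O`, is a shorter glycoside carrying an aminomethyl group rather than a sulfonate, and compound 1 gives 6%, a gap well beyond the scatter; no single-change step connects these two, so the values only show how far apart they lie.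

Compound 3, `CCCCCCCCCCCC(=O)OCC(CO)O[C@@H]1O[C@H](CS(=O)(=O)O)[C@@H](O)[C@H](O)[C@H]1O`, keeps the whole sugar, the sulfonate and the glycerol ester of compound 2 and alters one thing: hydrogen in place of hexyl on a saturated chain carbon, ten or more bonds along the chain from a carbonyl carbon. The ester chain simply ends sooner.

Going by the values given here, no measured pair isolates the effect of chain length, so the direction of the step is not fixed by the data. Because compound 2 gives 86% with the full chain, the expectation is that a shortened chain holds much of that inhibition, with some loss plausible; the step from compound 2 to compound 3 is estimated at a number 21 percentage points lower from compound 2 to compound 3 (beyond the scatter). Compound 3 is expected to give 65%, within a range from 35% to 90%.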

Compound 3, a percentage reported as inhibition, at one concentration (the size of the read-out at that concentration, not a potency): 31%
Beside the measured number, compound 3's estimate is 34 percentage points above it; measured number outside the range, below it.
By their numbers in this assay, from the lowest: compound 1; then compound 3; then compound 2.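

For the compounds shown here, this is the first comparison here that changes a single place, and it shows that the far end of the ester chain matters in this assay: putting hydrogen in place of hexyl on a saturated chain carbon, ten or more bonds along the chain from a carbonyl carbon, gives a large step, a number 55 percentage points lower from compound 2 to compound 3 (beyond the scatter). The sugar, the sulfonate and the glycerol ester are the same in both compounds, so this loss of inhibition at the one concentration tested goes with the removal of the hexyl alone. Nothing shown here accounts for why the end of the chain counts for this much.

Going by these compounds alone, two chain lengths give only two points, which leaves open whether inhibition fades steadily as the chain shortens or falls away sharply at a particular length, and whether a longer chain than the one in compound 2 would raise it further. Also open, as far as these compounds go, is how much of the inhibition depends on the sulfonate, a question that a carboxylic acid or an amine in its place, on the same long ester chain, would address directly.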